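A few compounds are considered here, and "the series" means these few. Any claim that something is new, unique, unknown or untested is made for them only; others in the source may bear on it.

Measured so far:
compound 1 `CN(C)CC[C@H](CSc1ccccc1)Nc1ccc(S(=O)(=O)NC(=O)c2ccc(N3CCC(=Cc4ccc(F)cc4)CC3)cc2)cc1[N+](=O)[O-]`, 600 nM
compound 2 `CN(C)CC[C@H](CSc1ccccc1)Nc1ccc(S(=O)(=O)NC(=O)c2ccc(N3CCC(=Cc4ccccc4Cl)CC3)cc2)cc1[N+](=O)[O-]`, 450 nM
compound 3 `CN(C)CC[C@H](CSc1ccccc1)Nc1ccc(S(=O)(=O)NC(=O)c2ccc(N3CCC(=Cc4ccccn4)CC3)cc2)cc1[N+](=O)[O-]`, 1380 nM

In a functional assay (FL5.12 cells, Mus musculus) with Apoptosis regulator Bcl-2 (Homo sapiens) as the target (on this read-out higher numbers stand for an effect only at larger amounts of compound and lower numbers for an effect already at smaller amounts), compound 3 carries the highest number of the three: a 2.3-fold higher number from compound 1 to compound 3 (0.36 log units; beyond the scatter) and a 3.1-fold higher number from compound 2 to compound 3 (0.49 log units; beyond the scatter), both beyond the scatter, whereas a 1.3-fold lower number from compound 1 to compound 2 (0.12 log units; within the scatter). Compound 4 `CN(C)CC[C@H](CSc1ccccc1)Nc1ccc(S(=O)(=O)NC(=O)c2ccc(N3CCC(=Cc4cccnc4)CC3)cc2)cc1[N+](=O)[O-]` differs from compound 3 only in pyridin-3-yl in place of pyridin-2-yl on a double-bonded chain carbon bound to a double-bonded ring carbon. For the measured compounds named here, no measured step moves the nitrogen within this ring; the two steps that touch compound 3 show only that pyridin-2-yl stands above the two phenyl variants in this assay. Going by the values given here, a shift of the ring nitrogen therefore has no precedent here, and no step beyond the scatter is expected. Compound 4 is estimated at 1000 nM, with a range from 400 nM to 3000 nM. The expected step is a 1.4-fold lower number from compound 3 to compound 4 (0.14 log units; within the scatter).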

Compound 4, half-maximal effective concentration: 5300 nM
The estimate for compound 4 lay 5.3-fold (0.72 log units) below the measured number; the measured number lies above the stated range.
By their numbers in this assay, from the lowest: compounds 2 and 1 (each within the scatter of the next); then compound 3; then compound 4.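

In this assay the position of the ring nitrogen matters at this place, on a double-bonded chain carbon bound to a double-bonded ring carbon: pyridin-3-yl in place of pyridin-2-yl gives a 3.8-fold higher number from compound 3 to compound 4 (0.58 log units; beyond the scatter), with the same atoms joined differently. Against the two phenyl variants, the change gives an 8.8-fold higher number from compound 1 to compound 4 (0.95 log units; beyond the scatter) and a 12-fold higher number from compound 2 to compound 4 (1.07 log units; beyond the scatter), so the penalty seen for pyridin-2-yl is not the same for both pyridines. Nothing available explains the difference between the two pyridines.

Open, as far as these compounds go, is how pyridin-4-yl would stand at this place. Also open, from the compounds shown here alone, is whether a methoxy group or an amine on the pyridin-3-yl ring would change its number.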